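Dropping the Chloro Substituent in a Seizure Model

A few compounds are considered here, and "the series" means these few. Any claim that something is new, unique, unknown or untested is made for them only; others in the source may bear on it.

Two compounds have so far been tested in a functional assay on the whole organism (strain Swiss) with Mus musculus as the target, in the maximal electroshock model, with a stated time of 0.5 h, at a dose of 300 mg/kg by the intraperitoneal route; a higher number here means a stronger effect of the compound at the dose given, a lower number a weaker effect:

Compound 1 `CCC(C(=O)N1CCN(c2ccc(C(F)(F)F)cc2)CC1)N1C(=O)CCC1=O`: 0%
Compound 2 `CCC(C(=O)N1CCN(c2ccc(Cl)cc2)CC1)N1C(=O)CCC1=O`: 0%

Compound 2 stands level with compound 1 at the digits shown, and the only measured step, no change at the digits printed from compound 1 to compound 2 (within the scatter), lies within the scatter, so neither measured compound showed any effect at the dose given. Compound 3 `CCC(C(=O)N1CCN(c2ccccc2)CC1)N1C(=O)CCC1=O` is the next candidate. It differs from compound 2 in one place: hydrogen in place of chloro on an aromatic carbon. Going by the values given here, the one known step, trifluoromethyl to chloro, also sat on an aromatic carbon and gave nothing beyond the scatter. The change leading to compound 3 is of the same kind, so the expectation for it is again no step beyond the scatter, no change at the digits printed from compound 2 to compound 3 (within the scatter) in this assay. Compound 3 is therefore estimated at 0%, within a range from 0% to 10%.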

Compound 3, a percentage reported as activity, at one dose (the size of the read-out at that dose, not a potency): 75%
Compound 3: middle estimate off by 75 percentage points, on the low side; the whole stated range lies below it.
By their numbers in this assay, from the lowest: compounds 1 and 2 (each within the scatter of the next); then compound 3.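

In this assay, replacing chloro with hydrogen on this aromatic carbon, para to a large group, gives a number 75 percentage points higher from compound 2 to compound 3 (beyond the scatter), and replacing trifluoromethyl with hydrogen gives a number 75 percentage points higher from compound 1 to compound 3 (beyond the scatter), so the position clearly matters. The earlier pair could not show this, as swapping one of these groups for the other left the read-out unchanged, whereas the plain phenyl now stands apart from both substituted compounds. No available data explain why hydrogen separates so sharply from chloro and trifluoromethyl.

The compounds shown leave open whether other groups at this position, such as fluoro, methyl, methoxy or an amine, would keep the effect of compound 3 or lose it. A read-out at one dose also leaves open how strong the effect of compound 3 would be at other doses, and what the other parts of the shared core contribute.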